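The source may report more compounds than this note shows. Statements on the series, on what has been measured and on what is new or still open speak of the compounds shown alone.

Measured compounds:
compound 1 `COc1ccc(-c2cc(/C=C/C(=O)c3ccc(OC)c(OC)c3)[nH]n2)cc1` gives 92%
compound 2 `COc1cc(-c2cc(/C=C/C(=O)c3ccc(Cl)c(Cl)c3)[nH]n2)cc(OC)c1OC` gives 96%
compound 3 `COc1ccc(-c2cc(/C=C/C(=O)c3cc(OC)c(OC)c(OC)c3)[nH]n2)cc1OC` gives 96%

All three readings come from a functional assay on UACC-257 cells (Homo sapiens) for cytotoxicity, read by sulforhodamine B assay, with a stated time of 48 h, tested at 0.01 uM; on this read-out higher numbers stand for a weaker effect at the one concentration tested and lower numbers for a stronger effect. Compound 2 reads the same as compound 3 at the digits shown, and compound 1 reads a few points lower, a gap that stays within the usual scatter; on these numbers compound 2 sits with the other two, and none of the three can be set apart from the others. At the single concentration used, every one of them leaves cell growth close to untouched.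

Compound 4 `COc1cc(-c2cc(/C=C/C(=O)c3ccc(F)c(F)c3)[nH]n2)cc(OC)c1OC` is the next member, not yet measured. It differs from compound 2 in one place: 3,4-difluorophenyl in place of 3,4-dichlorophenyl on a carbonyl carbon. Among the measured compounds shown here, the series gives no measured step between two compounds that differ in one place, so there is no direct precedent for this change. Given that compound 1 with 92%, compound 2 with 96% and compound 3 with 96% all lie in the same narrow band in this assay, the step from compound 2 to compound 4 is expected to be no larger than the scatter, in no particular direction, a number 1 percentage points lower from compound 2 to compound 4 (within the scatter). Compound 4 is accordingly estimated at 95%, with a range from 85% to 103%.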

Compound 4, a percentage reported as activity, at one concentration (the size of the read-out at that concentration, not a potency): 88%
For compound 4 the middle estimate is 7 percentage points above the measured one; measured number inside the range.
By their numbers in this assay, from the lowest: compounds 4, 1, 2 and 3 (each within the scatter of the next).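

In this assay, among the compounds shown here, the exchange of 3,4-dichlorophenyl for 3,4-difluorophenyl on a carbonyl carbon provides the first reading of a change made in one place, with a number 8 percentage points lower from compound 2 to compound 4 (within the scatter) as the step. At this position, the two halogen-bearing phenyl groups therefore cannot be told apart at the single concentration tested, and the step gives no evidence that this exchange alters the read-out. This one pair defines no trend for the position, and no supporting measurement is available to explain the small difference seen here.

From the compounds shown here alone, whether an amine, a carboxylic acid or a longer chain in place of the 3,4-difluorophenyl group on a carbonyl carbon would move the reading beyond the usual scatter remains open. Also open are the effect of changing the other parts of the shared core one at a time and the behaviour of these compounds at concentrations other than the single one used, where a stronger or weaker effect might be seen.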